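Ethyl for Cyclopropyl on a Sulfonamide Nitrogen

The source may report more compounds than this note shows. Statements on the series, on what has been measured and on what is new or still open speak of the compounds shown alone.

Measured compounds:
compound 1, `CC(C)c1noc(N2CCN(C(=O)[C@@H]3CCCN(S(=O)(=O)c4ccc(S(=O)(=O)NC5CC5)cc4)C3)CC2)n1`: > 10000 nM
compound 2, `CCOC(=O)N1CCC[C@H](S(=O)(=O)c2ccc(S(=O)(=O)N(CC)CC)cc2)C1`: > 10000 nM

Of the compounds shown here, two have been tested in a functional assay on MIA PaCa-2 cells (Homo sapiens) for inhibition, read by MTT assay, with a stated time of 3 days; a higher number here means a weaker inhibitor, a lower number a stronger inhibitor. Compound 1 carries a cyclopropyl group on a sulfonamide nitrogen. In this assay compound 1 gives > 10000 nM, which is a limit of the assay and not a number. Compound 2 is a different molecule, sharing no single-change relationship with compound 1. In this assay compound 2 gives > 10000 nM, again only a limit. Within the data shown here, both values shown sit at the same boundary (the limit of > 10000 nM in this assay, at which 2 of the 2 values shown sit), so compound 1 stands at the edge of what the assay reports, and no measured step exists between the two compounds.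

Compound 3, `CCNS(=O)(=O)c1ccc(S(=O)(=O)N2CCC[C@@H](C(=O)N3CCN(c4nc(C(C)C)no4)CC3)C2)cc1`, differs from compound 1 in one place: ethyl in place of cyclopropyl on a sulfonamide nitrogen. Among the measured compounds shown here, no measured pair shows this change. The step that the limit leaves unreadable from compound 1 to compound 3 is expected to be no larger than the usual scatter, because compound 1 already sits at the limit of > 10000 nM in this assay, at which 2 of the 2 values shown sit, and a small alkyl change at this position gives no reason to expect otherwise. Compound 3 is therefore estimated at 15000 nM, within a range from 5000 nM to 50000 nM, most likely reported again as a limit.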

Compound 3, half-maximal inhibitory concentration: > 10000 nM
Compound 3: no number, only a limit (the forecaster's own chance of this, stated with the estimate: 85%); the middle value is on the limit's open side.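

In this assay compound 3 gives > 10000 nM as a limit of the assay and not a number. Compound 1 also stands at a limit, so no step can be read for ethyl in place of cyclopropyl between compound 1 and compound 3: the limit of > 10000 nM in this assay, at which 3 of the 3 values shown sit.

The compounds shown leave open which structural change, if any, would give a readable value in this assay.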